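Carbamoyl cyclobutyl amine in place of hydroxycyclohexyl

This account rests on a few compounds, and the source may have more. Where it says the series, first, only, none or still open, it means among the compounds named here.

Working notes on the series. Three compounds share one core and differ only in the substituent on the amine nitrogen of the aromatic ring. In an assay on isolated protein for inhibition of protein kinase C theta type (Homo sapiens), read by TR-FRET, with a stated time of 2 h (a lower number here means a stronger inhibitor, a higher number a weaker inhibitor), compound 1 `N#Cc1cnc(NCc2cnccc2C(F)(F)F)cc1N[C@H]1C[C@H](O)C1` gives 900 nM, compound 2 `N#Cc1cnc(NCc2cnccc2C(F)(F)F)cc1NC[C@H]1C[C@@H](O)C1` gives 300 nM, and compound 3 `CC1(C)C[C@@H](Nc2cc(NCc3cnccc3C(F)(F)F)ncc2C#N)CC[C@@H]1O` gives 120 nM, the lowest number of the three and beyond the scatter from both others, so compound 3 is the strongest inhibitor measured. Compound 4 `CC1(C)[C@@H](Nc2cc(NCc3cnccc3C(F)(F)F)ncc2C#N)C[C@@H]1C(N)=O` carries 3-carbamoyl-2,2-dimethylcyclobutyl in place of 4-hydroxy-3,3-dimethylcyclohexyl on a nitrogen on an aromatic ring. The steps bearing on this position are a 7.5-fold lower number from compound 1 to compound 3 (0.88 log units; beyond the scatter) and a 2.5-fold lower number from compound 2 to compound 3 (0.40 log units; beyond the scatter), both modest and both favouring the 4-hydroxy-3,3-dimethylcyclohexyl group; none tests a carbamoyl group directly. A partial return toward the weaker numbers is expected, a 2.5-fold higher number from compound 3 to compound 4 (0.40 log units; beyond the scatter). Compound 4 is estimated at 300 nM, with a range from 80 nM to 1200 nM.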

Compound 4, half-maximal inhibitory concentration: 1100 nM
Estimate against measurement, compound 4: 3.7-fold (0.56 log units) below; measured number inside the range.
By their numbers in this assay, from the lowest: compound 3; then compound 2; then compounds 1 and 4 (each within the scatter of the next).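

In this assay, the 3-carbamoyl-2,2-dimethylcyclobutyl group does not keep the level of the 4-hydroxy-3,3-dimethylcyclohexyl group (a 9.2-fold higher number from compound 3 to compound 4 (0.96 log units; beyond the scatter)) or of the (3-hydroxycyclobutyl)methyl group (a 3.7-fold higher number from compound 2 to compound 4 (0.56 log units; beyond the scatter)). Against the 3-hydroxycyclobutyl group it cannot be told apart (within the scatter: a 1.2-fold higher number from compound 1 to compound 4 (0.09 log units; within the scatter)), so the two dimethyl-bearing groups do not share one level at this position. No measured evidence bears on the reason for these steps.

This change alters ring size and replaces hydroxyl with carbamoyl at once, so the compounds shown leave the two effects unseparated. A 4-carbamoyl-3,3-dimethylcyclohexyl or 3-hydroxy-2,2-dimethylcyclobutyl group would separate them.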